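Two Amides That Are Mirror Images of Each Other

The source may hold more compounds than are shown below. What is called first, only, known or untested is meant among the compounds shown, and "the series" means these compounds.

Measured so far:
Compound 1, `N#Cc1cc(N2C[C@H]3CCNC[C@H]32)cnc1Br`, 238 nM
Compound 2, `NC(=O)c1cc(N2C[C@@H]3CCNC[C@@H]32)cnc1Br`, 23300 nM

Both were tested in a functional assay on HEK293 cells for agonist activity at Neuronal acetylcholine receptor; alpha3/beta4 (Homo sapiens), read by FLIPR; a lower number here means that less compound is needed, a higher number that more compound is needed for the effect. Compound 2 has the higher of the two numbers, and compound 1 lies far below it, well beyond the usual scatter. Compound 3 `NC(=O)c1cc(N2C[C@H]3CCNC[C@H]32)cnc1Br` has not yet been measured. It differs from compound 2 as follows: the two compounds have the same atoms and bonds and differ only in configuration as drawn: 2 of 2 stereo elements differ (all stereocentres are inverted: mirror images); a stereocentre at a saturated ring carbon is drawn S in compound 2 and R in compound 3; a stereocentre at a saturated ring carbon is drawn R in compound 2 and S in compound 3. For the measured compounds named here, no measured pair here shows such a change, so its size is uncertain; mirror images often differ strongly, in either direction. The expected step from compound 2 to compound 3 is a 16-fold lower number from compound 2 to compound 3 (1.19 log units; beyond the scatter), toward a lower number. For compound 3 the estimate in this assay is 1500 nM, between 150 nM and 15000 nM.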

Compound 3, half-maximal effective concentration: 7460 nM
Estimate against measurement, compound 3: 5.0-fold (0.70 log units) below, within the range that was stated.
By their numbers in this assay, from the lowest: compound 1; then compound 3; then compound 2.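

Inverting both stereocentres gives a 3.1-fold lower number from compound 2 to compound 3 (0.49 log units; beyond the scatter) and nothing else separates the pair, so this modest step can be put down to configuration alone: the fact that compounds 2 and 3 differ only in the configuration as drawn. With the configuration held, carbamoyl in place of cyano on the aromatic carbon gives a 31-fold higher number from compound 1 to compound 3 (1.50 log units; beyond the scatter) and this large step shows that the choice of group there outweighs the mirror-image change in this pair.

As far as these compounds go, whether the nitrile series shows the same preference between mirror images stays open. So does how a carboxylic acid or a methyl ester would behave on that carbon.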